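A Single Chlorine in Place of Two

This account rests on a few compounds, and the source may have more. Where it says the series, first, only, none or still open, it means among the compounds named here.

In a functional assay on A549 cells (Homo sapiens) for inhibition, read by MTT assay, with a stated time of 48 h (a higher number here means a weaker inhibitor, a lower number a stronger inhibitor), compound 1 `Nc1n[nH]c2cccc(-c3cccc(NC(=O)Nc4cccc(F)c4)c3)c12`, with a 3-fluorophenyl group, gives 1360 nM. Compound 2 `Nc1n[nH]c2cccc(-c3cccc(NC(=O)Nc4ccc(Cl)cc4Cl)c3)c12`, with a 2,4-dichlorophenyl group, gives no number, only a limit of the assay: > 500000 nM. Within the data shown here, the single measured step between them is an at least 360-fold higher number from compound 1 to compound 2 (2.56 log units; beyond the scatter). Among the measured compounds shown here, it is a large step, and it is the only guide here.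

Compound 3 `Nc1n[nH]c2cccc(-c3cccc(NC(=O)Nc4cccc(Cl)c4)c3)c12` has 3-chlorophenyl in place of 2,4-dichlorophenyl on an amide-type nitrogen. On paper, the 3-chlorophenyl group of compound 3 resembles the 3-fluorophenyl group of compound 1, which gives 1360 nM. Much of the earlier large step is therefore expected to be undone, with the number falling and the inhibitor growing stronger in this assay. The expected change is an at least 200-fold lower number from compound 2 to compound 3 (2.30 log units; beyond the scatter). For the measured compounds named here, no measured compound yet shows how chlorine compares with fluorine in this group, so the range stays wide. Compound 3 is estimated at 2500 nM, with an expected range from 500 nM to 30000 nM.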

Compound 3, half-maximal inhibitory concentration: 1720 nM
Compound 3: the middle estimate sits 1.5-fold (0.16 log units) above what was measured; the measured number falls inside the stated range.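

In this assay, 3-chlorophenyl in place of 2,4-dichlorophenyl on the amide-type nitrogen gives an at least 290-fold lower number from compound 2 to compound 3 (2.46 log units; beyond the scatter), which shows that a chlorine on this ring does not by itself bring the loss seen with compound 2. Chloro in place of fluoro on the aromatic carbon gives a 1.3-fold higher number from compound 1 to compound 3 (0.10 log units; within the scatter), which lies within the scatter, so compound 1 and compound 3 cannot be told apart and this one halogen swap makes no measurable difference here. The true size of the large step remains unknown because compound 2 gives a limit of the assay and not a number: the limit of > 500000 nM in this assay, at which 1 of the 3 values shown sits.

The 3-chlorophenyl and 2,4-dichlorophenyl groups differ both in how many chlorines they carry and in where those chlorines sit, and the compounds shown cannot separate these two differences. On these data alone, it also remains open how this assay would read for a phenyl ring carrying a methoxy or trifluoromethyl group in place of the halogen.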